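From 2-methoxyphenyl to 4-methoxyphenyl on the amine nitrogen

The source may report more compounds than this note shows. Statements on the series, on what has been measured and on what is new or still open speak of the compounds shown alone.

Of the compounds shown here, three sharing one core have so far been measured in a functional assay on MCF7 cells (Homo sapiens) for inhibition, read by sulforhodamine B assay (a lower number here means a stronger inhibitor, a higher number a weaker inhibitor), and differ only in the aryl group on the amine nitrogen. Compound 1 `CCc1ccc(NC2=CC(=O)c3c(nc4n3[C@H]3OC[C@@H](O)[C@H]3OC4)C2=O)cc1` carries 4-ethylphenyl and gives 8990 nM there. Compound 2 `Cc1ccc(NC2=CC(=O)c3c(nc4n3[C@H]3OC[C@@H](O)[C@H]3OC4)C2=O)cc1C` carries 3,4-dimethylphenyl and gives 4950 nM in the same test. Compound 3 `COc1ccccc1NC1=CC(=O)c2c(nc3n2[C@H]2OC[C@@H](O)[C@H]2OC3)C1=O` carries 2-methoxyphenyl and gives 6580 nM, which places it within the scatter of both others, so the three cannot be put in order.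

The next compound is compound 4 `COc1ccc(NC2=CC(=O)c3c(nc4n3[C@H]3OC[C@@H](O)[C@H]3OC4)C2=O)cc1`, and the change is 4-methoxyphenyl in place of 2-methoxyphenyl on an amine nitrogen. The two have the same atoms, joined differently. Within the data shown here, no measured step moves a methoxy group, so the only guidance comes from the other exchanges on this nitrogen. These are a 1.8-fold lower number from compound 1 to compound 2 (0.26 log units; within the scatter), a 1.4-fold lower number from compound 1 to compound 3 (0.14 log units; within the scatter) and a 1.3-fold higher number from compound 2 to compound 3 (0.12 log units; within the scatter), and all of them stay within the scatter. On that evidence, no step beyond the scatter is expected in this assay, in either direction. The estimated step is a 1.1-fold lower number from compound 3 to compound 4 (0.04 log units; within the scatter) and it would lie within the scatter. Compound 4 is expected at 6000 nM with an estimated range from 2500 nM to 14000 nM for the coming measurement.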

Compound 4, half-maximal inhibitory concentration: 4470 nM
The estimate for compound 4 lay 1.3-fold (0.13 log units) above the measured number; low and high end bracket the measured number.
By their numbers in this assay, from the lowest: compounds 4, 2, 3 and 1 (each within the scatter of the next).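

Moving the methoxy group, from 2-methoxyphenyl to 4-methoxyphenyl with the same atoms joined differently, gives a 1.5-fold lower number from compound 3 to compound 4 (0.17 log units; within the scatter) in this assay, so this first test of where the group sits on the aryl ring shows no step beyond the scatter. Against the other aryl groups on this amine nitrogen, the 4-methoxyphenyl compound shows a 1.1-fold lower number from compound 2 to compound 4 (0.04 log units; within the scatter) for the exchange with 3,4-dimethylphenyl and a 2.0-fold lower number from compound 1 to compound 4 (0.30 log units; within the scatter) for methoxy in place of ethyl, the largest step in the series so far, though still printed as within the scatter. All four aryl groups therefore lie within the scatter of one another, and this set of compounds gives no ranking among them at this position.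

As far as these compounds go, it remains open whether a group of another kind on the aryl ring, such as a carboxylic acid, an amine or a longer alkyl chain, or a cyclohexyl group in place of the aryl ring, would produce a step beyond the scatter. No supporting data are available to account for these numbers.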